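Hydrazone substituent exchange on the shared amine nitrogen

The source may report more compounds than this note shows. Statements on the series, on what has been measured and on what is new or still open speak of the compounds shown alone.

For the measured compounds named here, of the two numbers measured so far, compound 1 `CCOC(=O)C1=C(NN=C(C(C)=O)C(C)=O)Nc2[nH]nc(C)c2C1c1ccc(N(C)C)cc1` gives 17000 nM in a functional assay on HeLa cells (Homo sapiens) for inhibition, read by MTT assay, with a stated time of 48 h (on this read-out higher numbers stand for weaker inhibition and lower numbers for stronger inhibition), and compound 2 `CCOC(=O)C1=C(NN=C(C#N)C#N)Nc2[nH]nc(C)c2C1c1ccc(N(C)C)cc1` gives 15200 nM in this assay; a 1.1-fold lower number from compound 1 to compound 2 (0.05 log units; within the scatter). Compound 3 `CCOC(=O)C(=NNC1=C(C(=O)OCC)C(c2ccc(N(C)C)cc2)c2c(C)n[nH]c2N1)C(=O)OCC` is not yet measured and differs from compound 1 by a group of 12 heavy atoms (7 carbon, 1 nitrogen, 4 oxygen; no ring) in place of a group of 8 heavy atoms (5 carbon, 1 nitrogen, 2 oxygen; no ring), on an amine nitrogen. Going by the values given here, the only measured step bears on it directly, since it exchanged the same group on the same amine nitrogen, and it stayed within the scatter. Compound 3 is therefore expected to show no change at the digits printed from compound 1 to compound 3 (within the scatter), nothing beyond the scatter. The estimate for compound 3 is 17000 nM, with a range from 6000 nM to 48000 nM.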

Compound 3, half-maximal inhibitory concentration: 83800 nM
For compound 3 the middle estimate is 4.9-fold (0.69 log units) below the measured one; measured number above the stated range.
By their numbers in this assay, from the lowest: compounds 2 and 1 (each within the scatter of the next); then compound 3.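

This amine nitrogen does respond to the group it carries: in this assay the group of 12 heavy atoms gives a 4.9-fold higher number from compound 1 to compound 3 (0.69 log units; beyond the scatter) and a 5.5-fold higher number from compound 2 to compound 3 (0.74 log units; beyond the scatter) with both steps beyond the scatter, a separation the earlier exchange did not show. Compounds 1 and 2 remain within the scatter of each other, so the change so far sets compound 3 apart from that pair alone. No supporting data bear on this result. With only three groups shown, it remains open whether the number tracks heavy-atom count. A carboxylic acid or a primary amine at the end of the group on this nitrogen would test that further.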